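Adding an amino group to compound 1: expecting compound 4

A few compounds are considered here, and "the series" means these few. Any claim that something is new, unique, unknown or untested is made for them only; others in the source may bear on it.

Measured in a functional assay on HL-60 cells (Homo sapiens) for antiproliferative activity; a lower number here means a stronger inhibitor, a higher number a weaker inhibitor:
Compound 1 `COc1ccc(-c2snnc2-c2cc(OC)c(OC)c(OC)c2)cc1`: 14.5 nM
Compound 2 `COc1cc(-c2nnsc2-c2ccc(Cl)cc2)cc(OC)c1OC`: 23.6 nM
Compound 3 `COc1cc(-c2nnsc2-c2ccc([N+](=O)[O-])cc2)cc(OC)c1OC` gives only a limit: > 1000 nM

Compound 1 holds the lowest of the two numbers; compound 2 sits within the scatter of it, a 1.6-fold higher number from compound 1 to compound 2 (0.21 log units; within the scatter). Compound 3 sits at the limit described by the limit of > 1000 nM in this assay, at which 1 of the 3 values shown sits, and the steps of an at least 68-fold higher number from compound 1 to compound 3 (1.83 log units; beyond the scatter) and an at least 42-fold higher number from compound 2 to compound 3 (1.62 log units; beyond the scatter) are large.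

Compound 4 `COc1ccc(-c2snnc2-c2cc(OC)c(OC)c(OC)c2)cc1N` differs from compound 1 by amino in place of hydrogen on an aromatic carbon. The measured steps all exchange the methoxy itself; none keeps the methoxy and adds a group ortho to it, so none bears directly on this change. The benign step a 1.6-fold higher number from compound 1 to compound 2 (0.21 log units; within the scatter) suggests the ring tolerates some variation; the large steps to compound 3 warn that a polar entering group can cost much. The step expected for compound 4 is a 1.7-fold higher number from compound 1 to compound 4 (0.24 log units; within the scatter), a mild loss within the scatter. Compound 4 is estimated at 25 nM, between 8 nM and 80 nM.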

Compound 4, half-maximal inhibitory concentration: 1.8 nM
Beside the measured number, compound 4's estimate is 14-fold (1.14 log units) above it; the measured number lies below the stated range.
By their numbers in this assay, from the lowest: compound 4; then compounds 1 and 2 (each within the scatter of the next). At a limit, above all of these: compound 3.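

Amino on an aromatic carbon ortho to a methoxy group, with the methoxy kept, gives an 8.1-fold lower number from compound 1 to compound 4 (0.91 log units; beyond the scatter), so this position takes an entering group with a gain beyond the scatter. The earlier steps shown here exchanged only the methoxy itself and said nothing about this carbon. Nothing measured here accounts for the gain.

On these data alone, whether the gain is specific to amino stays open, as a hydroxyl, a methylamino or an acetamido group on this carbon would show. Also open, as far as these compounds go, is whether amino gives a similar step with chloro in place of the methoxy.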